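Allyl for cyclopentyl on the amine of a pyrrolopyrimidine core

This account rests on a few compounds, and the source may have more. Where it says the series, first, only, none or still open, it means among the compounds named here.

Measured so far:
Compound 1 `Cc1nc(NC2CCC2)c2cc[nH]c2n1` — 74100000 nM
Compound 2 `Cc1nc(NC2CCCC2)c2cc[nH]c2n1` — 72400000 nM

In a functional assay on the whole organism for inhibition, with Nicotiana tabacum as the target (a higher number here means a weaker inhibitor, a lower number a stronger inhibitor), compound 1 gives 74100000 nM and compound 2 gives 72400000 nM. Compound 2 stands beside compound 1 on these numbers, with a 1.0-fold lower number from compound 1 to compound 2 (0.01 log units; within the scatter), so the two cannot be told apart. Compound 3 `C=CCNc1nc(C)nc2[nH]ccc12` differs from compound 2 only in allyl in place of cyclopentyl on a nitrogen on an aromatic ring. Among the measured compounds shown here, the single measured step bearing on it, a 1.0-fold lower number from compound 1 to compound 2 (0.01 log units; within the scatter), shows that swapping one ring for another on this nitrogen changed nothing beyond the scatter. The step to compound 3 is of the same kind and is therefore expected to be a 1.0-fold lower number from compound 2 to compound 3 (0.01 log units; within the scatter), with no direction beyond the scatter. Compound 3 is thus expected to give about 70000000 nM, within 25000000 nM to 200000000 nM.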

Compound 3, half-maximal inhibitory concentration: 676000000 nM
Estimate against measurement, compound 3: 9.7-fold (0.98 log units) below; measured number outside the range, above it.
By their numbers in this assay, from the lowest: compounds 2 and 1 (each within the scatter of the next); then compound 3.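

In this assay, this nitrogen turns out not to be indifferent to its substituent: allyl in place of cyclopentyl gives a 9.3-fold higher number from compound 2 to compound 3 (0.97 log units; beyond the scatter), and allyl in place of cyclobutyl gives a 9.1-fold higher number from compound 1 to compound 3 (0.96 log units; beyond the scatter), although the two rings themselves could not be told apart. Compound 3, with no ring on this nitrogen, is thus the weakest inhibitor of the three. No evidence at hand accounts for this difference.

From the compounds shown here alone, it remains open whether the ring, the size of the group or the double bond of allyl sets the difference. A saturated propyl chain, a cyclopropyl ring or a longer chain such as pentyl on this nitrogen would help separate these readings.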